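Phenyl for Methyl on a Thiazole-Type Core, Twice Over

The source may report more compounds than this note shows. Statements on the series, on what has been measured and on what is new or still open speak of the compounds shown alone.

Compound 1 `Cc1csc(N/N=C/c2ccccc2)n1` is the reference point of this set. In an assay on mitochondria for inhibition of Amine oxidase [flavin-containing] B (Bos taurus) (on this read-out lower numbers stand for stronger inhibition and higher numbers for weaker inhibition), compound 1 gives 1.32 nM. Compound 2 `C(=N/Nc1nc(-c2ccccc2)cs1)\c1ccccc1` carries one change, (phenyl in place of methyl on an aromatic carbon), and in this assay compound 2 gives 91.2 nM, so that a 69-fold higher number from compound 1 to compound 2 (1.84 log units; beyond the scatter). Compound 3 `Cc1ccc(/C=N/c2nc(C)cs2)cc1` rests on a different core; the difference between the two cores is not broken down here. In this assay compound 3 gives 832 nM, the highest number among the three, and the gap from compound 2 to compound 3 lies beyond the scatter.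

Compound 4 `Cc1ccc(/C=N/c2nc(-c3ccccc3)cs2)cc1` has not yet been measured. It differs from compound 3 by phenyl in place of methyl on an aromatic carbon, the same change as from compound 1 to compound 2, made at the same place. If the change carried over, compound 4 would be expected to show a 24-fold higher number from compound 3 to compound 4 (1.38 log units; beyond the scatter), resting on a 69-fold higher number from compound 1 to compound 2 (1.84 log units; beyond the scatter) and on compound 3 giving 832 nM. The core of compound 3 is not that of compound 1, and the size of the step is therefore uncertain. Compound 4 is estimated at 20000 nM, between 3000 nM and 150000 nM.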

Compound 4, inhibition constant: 0.813 nM
For compound 4 the middle estimate is 25000-fold (4.39 log units) above the measured one, and the stated range ends above it.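

Phenyl in place of methyl on an aromatic carbon gives a 1000-fold lower number from compound 3 to compound 4 (3.01 log units; beyond the scatter) in this assay, so the change that weakened inhibition on the core of compound 1 strengthens it on the core of compound 3. The change therefore does not carry over between these two cores, in either direction or size: the same change on two cores in this assay, a 69-fold higher number (1.84 log units; beyond the scatter) from compound 1 to compound 2 and a 1000-fold lower number (3.01 log units; beyond the scatter) from compound 3 to compound 4, 71000-fold (4.85 log units) apart, beyond the scatter of two such steps This shows that, in this series, a step measured on one of these cores is no guide to the same step on the other, but it rests on a single pair per core and does not show which part of the difference between the cores goes with the reversal.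

The compounds shown leave open how each core responds at this carbon to groups other than methyl and phenyl, such as an amine or a carboxylic acid. They also leave open whether a longer chain there would follow methyl or phenyl on either core.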